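This account rests on a few compounds, and the source may have more. Where it says the series, first, only, none or still open, it means among the compounds named here.

Series notes. Compound 1 `CCOC(=O)C1=C(N/N=C(\C#N)C(N)=O)Nc2[nH]nc(C)c2C1c1ccc(N(C)C)cc1` gives 50100 nM in a functional assay on MCF7 cells (Homo sapiens) for inhibition, read by MTT assay, with a stated time of 48 h; on this read-out higher numbers stand for weaker inhibition and lower numbers for stronger inhibition. Within the data shown here, compound 2 `CCOC(=O)C1=C(N/C=N/c2ccccn2)Nc2[nH]nc(C)c2C1c1ccc(N(C)C)cc1` gives 37300 nM in this assay; the only measured step is a 1.3-fold lower number from compound 1 to compound 2 (0.13 log units; within the scatter), so compound 2 holds the lower-placed of the two numbers while compound 1 sits within the scatter of it. Compound 3 `CCOC(=O)C1=C(N/N=C(/C(C)=O)C(=O)OCC)Nc2[nH]nc(C)c2C1c1ccc(N(C)C)cc1` changes the same amine nitrogen: a group of 10 heavy atoms (6 carbon, 1 nitrogen, 3 oxygen; no ring) in place of a group of 8 heavy atoms (6 carbon, 2 nitrogen; one six-membered aromatic ring with 1 hetero atom), on an amine nitrogen. Among the measured compounds shown here, the one measured change at that place, a 1.3-fold lower number from compound 1 to compound 2 (0.13 log units; within the scatter), stayed within the scatter, so for compound 3 no step beyond the scatter is expected in this assay. Compound 3 is estimated at 40000 nM, range 15000 nM to 110000 nM. The expected step is a 1.1-fold higher number from compound 2 to compound 3 (0.03 log units; within the scatter).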

Compound 3, half-maximal inhibitory concentration: > 100000 nM
Compound 3 ended at the assay's limit (the forecaster's own chance of this, stated with the estimate: 10%); middle value at least 2.5-fold (0.39 log units) away from the limit.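

Compound 3 reads as a limit of this assay, not as a number: the limit of > 100000 nM in this assay, at which 1 of the 3 values shown sits.

Among these compounds, this is the first change at the amine nitrogen to give a step beyond the scatter: with the group of 10 heavy atoms and no ring replacing the group with one six-membered aromatic ring, the number rises (an at least 2.6-fold higher number from compound 2 to compound 3 (0.42 log units; beyond the scatter)). The comparison with the other open-chain group is less firm (an at least 1.9-fold higher number from compound 1 to compound 3 (0.30 log units; that floor lies within the scatter)).

On these data alone, the true size of both steps stays open past the limit. Also open, as far as these compounds go, is whether a plain phenyl group or a carboxylic acid on this nitrogen would stay nearer compound 2 or compound 3.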